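This account rests on a few compounds, and the source may have more. Where it says the series, first, only, none or still open, it means among the compounds named here.

In a functional assay on THP-1 cells (Homo sapiens) for cytotoxicity, read by sulforhodamine B assay, with a stated time of 48 h (on this read-out higher numbers stand for weaker inhibition and lower numbers for stronger inhibition), compound 1 `COc1cc(/C=C/C(=O)/C=C/c2cccc3ccccc23)ccc1OCc1cn(CCOc2cc(=O)oc3ccccc23)nn1` gives 4480 nM and compound 2 `COc1cc(/C=C/C(=O)/C=C/c2cccc3ccccc23)ccc1OCc1cn(CCCOc2cc(=O)oc3ccccc23)nn1` gives 8410 nM while compound 3 `COc1cccc(/C=C/C(=O)/C=C/c2ccc(OCc3cn(CCOc4cc(=O)oc5ccccc45)nn3)c(OC)c2)c1` stands at 7130 nM within the scatter of both. Compound 4 `COc1ccc(/C=C/C(=O)/C=C/c2ccc(OCc3cn(CCOc4cc(=O)oc5ccccc45)nn3)c(OC)c2)cc1OC` differs from compound 3 by one change: methoxy in place of hydrogen on an aromatic carbon with methoxy in place of hydrogen on an aromatic carbon, so that 3-methoxyphenyl becomes 3,4-dimethoxyphenyl. Going by the values given here, the one measured step at this end of the molecule is a 1.6-fold higher number from compound 1 to compound 3 (0.20 log units; within the scatter) for 3-methoxyphenyl in place of naphthalen-1-yl. Among the compounds with values here, no measured step adds a methoxy group on its own. Nothing beyond the scatter is therefore expected in this assay for this change. The expected step is a 1.1-fold lower number from compound 3 to compound 4 (0.04 log units; within the scatter) and no larger. Compound 4 is estimated at 6500 nM with an expected range from 3000 nM to 14000 nM on this read-out.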

Compound 4, half-maximal inhibitory concentration: 2340 nM
Beside the measured number, compound 4's estimate is 2.8-fold (0.44 log units) above it, and the stated range ends above it.
By their numbers in this assay, from the lowest: compounds 4, 1, 3 and 2 (each within the scatter of the next, the first and the last beyond it).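

In this assay, going by these compounds alone, methoxy on the aromatic carbon ortho to a methoxy group and para to a large group gives a 3.0-fold lower number from compound 3 to compound 4 (0.48 log units; beyond the scatter), the first single-place step beyond the scatter. Against naphthalen-1-yl, however, 3,4-dimethoxyphenyl gives a 1.9-fold lower number from compound 1 to compound 4 (0.28 log units; within the scatter), so these two end groups remain unseparated. No evidence on the origin of the methoxy step is available.

Open, on these data alone, is whether a hydroxy group or a dimethylamino group in the same place would give a similar step. Also open, as far as these compounds go, is whether the step carries over to the longer chain of compound 2.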